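A few compounds are considered here, and "the series" means these few. Any claim that something is new, unique, unknown or untested is made for them only; others in the source may bear on it.

Series notes. Compound 1 `COc1ccc2[nH]cc(C(=O)/C(C#N)=C/C=C(\Cl)c3ccc(Br)cc3)c2c1` carries a methoxy on the core; in a functional assay on MCF7 cells (Homo sapiens) for cytotoxicity, read by sulforhodamine B assay, with a stated time of 48 h (on this read-out lower numbers stand for higher toxicity in this test and higher numbers for lower toxicity in this test), compound 1 gives > 100000 nM, which is a limit of the assay. Compound 2 `N#C/C(=C\C=C(/Cl)c1ccc(Br)cc1)C(=O)c1c[nH]c2ccccc12` lacks that methoxy; in this assay compound 2 gives > 100000 nM, again a limit. The step that the two limits leave unreadable from compound 1 to compound 2 is therefore unreadable, and compound 2 stands at the limit of > 100000 nM in this assay, at which 2 of the 2 values shown sit. Compound 3 `N#C/C(=C\C=C(/Cl)c1ccc(Br)cc1)C(=O)c1c[nH]c2ccc(Br)cc12` differs from compound 2 by bromo in place of hydrogen on an aromatic carbon. For the measured compounds named here, no measured step reads on this change, so no step beyond the scatter is expected in this assay, with a number no higher from compound 2 to compound 3 (the limit leaves the size open) estimated; compound 3 is expected at 100000 nM, in the range 30000 nM to 300000 nM.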

Compound 3, concentration lethal to 50% of the cells: > 100000 nM
Compound 3: no number, only a limit (the forecaster's own chance of this, stated with the estimate: 75%); the middle value lies on the limit itself.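

No step can be read among compound 1, compound 2 and compound 3 in this assay, where each gives only a limit of the assay: the limit of > 100000 nM in this assay, at which 3 of the 3 values shown sit. On these data alone, what methoxy, hydrogen or bromo at this place on the core does to the read-out stays open.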